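This account rests on a few compounds, and the source may have more. Where it says the series, first, only, none or still open, it means among the compounds named here.

Compound 1 `CC1(C)C/C(=N\OC(=O)c2cccc(NC(=O)c3cccc(F)c3)c2)c2c(-c3cccc(F)c3)noc2C1` in a functional assay on HCC1954 cells (Homo sapiens) for antiproliferative activity, read by MTT assay, with a stated time of 72 h (on this read-out lower numbers stand for stronger inhibition and higher numbers for weaker inhibition), gives > 25000 nM, which is a limit of the assay rather than a number.
Compound 2 `CC1(C)C/C(=N\OC(=O)c2cccc(NC(=O)c3cccc(F)c3)c2)c2c(noc2-c2cccc(F)c2)C1` in this assay gives > 25000 nM, again a limit and not a number.
Compound 3 `COc1ccc(-c2noc3c2/C(=N/OC(=O)c2cccc(NC(=O)c4cccc(F)c4)c2)CC(C)(C)C3)cc1OC` in this assay gives > 25000 nM, once more a limit.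

Compounds 1 and 2 are built from the same atoms joined differently; the difference between the two cores is not broken down here. Compound 3 arises from compound 1 by 3,4-dimethoxyphenyl in place of 3-fluorophenyl on an aromatic carbon, and the step it makes is a step that the two limits leave unreadable from compound 1 to compound 3, since the limit of > 25000 nM in this assay, at which 3 of the 3 values shown sit, puts both ends of that step at the same limit.

Compound 4 `COc1ccc(-c2onc3c2/C(=N/OC(=O)c2cccc(NC(=O)c4cccc(F)c4)c2)CC(C)(C)C3)cc1OC` is not yet measured. It arises from compound 2 by 3,4-dimethoxyphenyl in place of 3-fluorophenyl on an aromatic carbon. Going by the values given here, this is the same kind of change as the one from compound 1 to compound 3, but not the same: in compound 3 the new group sits next to the ring nitrogen and two ring bonds from the ring oxygen, whereas in compound 4 it sits next to the ring oxygen and two ring bonds from the ring nitrogen.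

Among the compounds with values here, because the limit of > 25000 nM in this assay, at which 3 of the 3 values shown sit, shows every value so far at the limit, compound 4 is expected to stay there too, with an expected step that the limit leaves unreadable from compound 2 to compound 4. Compound 4 is therefore estimated at 30000 nM in this assay, within an expected range from 10000 nM to 100000 nM.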

Compound 4, half-maximal inhibitory concentration: > 25000 nM
Compound 4 ended at the assay's limit; the forecaster's own chance of this, stated with the estimate: 85%; the middle value does not contradict the limit.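

Compound 4 in this assay gives > 25000 nM, which is a limit and not a number. Compound 2 also stands at a limit, so no step can be read from compound 2 to compound 4. Left open is how strongly any of the four compounds acts on these cells, and whether exchanging 3-fluorophenyl for 3,4-dimethoxyphenyl changes that at all: the limit of > 25000 nM in this assay, at which 4 of the 4 values shown sit.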